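Removing the Bromine: Compound 4 Awaits a Cytotoxicity Value

The source may report more compounds than this note shows. Statements on the series, on what has been measured and on what is new or still open speak of the compounds shown alone.

Compound 1 `Cc1ccc(S(=O)(=O)Oc2ccc3c(c2C)[C@H](Cn2cc(-c4ccccc4)nn2)[C@@]24CC(=O)[C@@](C)(CC[C@@H]32)C4)cc1`: in a functional assay on A549 cells (Homo sapiens) for cytotoxicity, read by MTT assay, with a stated time of 4 days (on this read-out lower numbers stand for stronger inhibition and higher numbers for weaker inhibition), compound 1 gives > 20000 nM, a limit.
Compound 2 `C=C1C[C@]23C[C@@]1(O)CC[C@@H]2c1cccc(C)c1[C@@H]3Cn1cc(-c2ccc(OC)cc2)nn1`: in this assay compound 2 gives > 20000 nM, a limit.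
Compound 3 `C=C1C[C@]23C[C@@]1(O)CC[C@@H]2c1cccc(C)c1[C@@H]3Cn1cc(-c2ccc(Br)cc2)nn1`: in this assay compound 3 gives > 20000 nM, a limit.

Within the data shown here, compound 3 therefore stands at the assay limit, where every value so far sits (the limit of > 20000 nM in this assay, at which 3 of the 3 values shown sit). Compound 4 `C=C1C[C@]23C[C@@]1(O)CC[C@@H]2c1cccc(C)c1[C@@H]3Cn1cc(-c2ccccc2)nn1` differs from compound 3 by hydrogen in place of bromo on an aromatic carbon. Among the measured compounds shown here, the only measured step of comparable kind, a step that the two limits leave unreadable from compound 2 to compound 3, cannot be read because both ends are limits, so no step size beyond the scatter is supported in either direction. Compound 4 is expected to remain at the limit, with an estimate of 30000 nM between 10000 nM and 100000 nM. The expected step is a step that the limit leaves unreadable from compound 3 to compound 4.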

Compound 4, half-maximal inhibitory concentration: > 20000 nM
Compound 4: a limit, no number; the forecaster's own chance of this, stated with the estimate: 85%; the middle value does not contradict the limit.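

Compound 4 gives > 20000 nM in this assay, which is a limit and not a number. No step from compound 2 or compound 3 to compound 4 can be read, as all the values share one limit: the limit of > 20000 nM in this assay, at which 4 of the 4 values shown sit.

The compounds shown leave open what real potency any of them has on these cells.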